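This account rests on a few compounds, and the source may have more. Where it says the series, first, only, none or still open, it means among the compounds named here.

In a functional assay on A549 cells (Homo sapiens) for antiproliferative activity, read by CCK-8 assay, with a stated time of 72 h (a lower number here means a stronger inhibitor, a higher number a weaker inhibitor), compound 1 (`C/C(=N\O)c1ccc(OCc2ccc(C(=O)NO)cc2)cc1`) gives 8930 nM and compound 2 (`Nc1ccccc1NC(=O)c1ccc(COc2ccc(Br)cc2)cc1`) gives 24400 nM as the higher of the two numbers, a gap beyond the scatter. Compound 3 (`CCCc1ccc(OCc2ccc(C(=O)Nc3ccccc3N)cc2)cc1`) differs from compound 2 in one place (propyl in place of bromo on an aromatic carbon), with propyl in place of bromo on an aromatic carbon. Going by the values given here, no measured step bears on this change, so no shift beyond the scatter is expected in this assay here. The expected step (a 1.2-fold lower number from compound 2 to compound 3 (0.09 log units; within the scatter)) is small, and its direction is uncertain. Compound 3 is estimated at 20000 nM and expected to fall between 8000 nM and 50000 nM in repeated measurements.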

Compound 3, half-maximal inhibitory concentration: 5210 nM
Compound 3: middle estimate off by 3.8-fold (0.58 log units), on the high side; measured number below the stated range.
By their numbers in this assay, from the lowest: compounds 3 and 1 (each within the scatter of the next); then compound 2.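

In this assay, the change from 4-bromophenyl to 4-propylphenyl gives a 4.7-fold lower number from compound 2 to compound 3 (0.67 log units; beyond the scatter), so the group on this aromatic carbon, para to a large group, matters to the read-out. Neither group carries hydrogen-bond donors or acceptors, so the shift comes with no change in those counts. Nothing measured here gives a reason for it. Going by these compounds, whether a longer chain, a methoxy group or an amine at this position would follow propyl stays open. So does whether the same change would act alike on the core of compound 1.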